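This account rests on a few compounds, and the source may have more. Where it says the series, first, only, none or still open, it means among the compounds named here.

Measured so far in a functional assay with Neuronal acetylcholine receptor; alpha3/beta4 (Homo sapiens) as the target; a higher number here means a weaker inhibitor, a lower number a stronger inhibitor:

Compound 1 `CCC1CC(=O)N(c2ccccc2C(=O)OCC2CCCN(CCCc3ccccc3)C2)C1=O` gives 4500 nM.
Compound 2 `O=C(OCC1CCCN(CCCc2ccccc2)C1)c1ccccc1F` gives 5200 nM.

Compound 2 has the highest of the two numbers, but its nearest neighbour, compound 1, lies within the scatter, so the two compounds cannot be separated on these data. Compound 3 `O=C(OCC1CCCN(CCCc2ccccc2)C1)c1ccccc1N1C(=O)c2ccccc2C1=O` arises from compound 2 by the change (a group of 11 heavy atoms (8 carbon, 1 nitrogen, 2 oxygen; one five-membered non-aromatic ring with 1 hetero atom, one six-membered aromatic ring of carbon only) in place of one fluorine atom, on an aromatic carbon). Within the data shown here, only one measured step bears on this: a 1.2-fold higher number from compound 1 to compound 2 (0.06 log units; within the scatter), in which a group of 9 heavy atoms with one five-membered non-aromatic ring gave way to a single fluorine without any change beyond the scatter. The move to compound 3 runs the other way, putting back a larger group of the same general kind, with one five-membered non-aromatic ring and one six-membered aromatic ring, at the same aromatic carbon. On the strength of that single step, no change beyond the scatter is expected in this assay, and the estimated step is a 1.2-fold lower number from compound 2 to compound 3 (0.06 log units; within the scatter). For compound 3 the expected value is 4500 nM, with a likely range from 1800 nM to 11000 nM.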

Compound 3, half-maximal inhibitory concentration: 1300 nM
Beside the measured number, compound 3's estimate is 3.5-fold (0.54 log units) above it, outside the stated range (below it).
By their numbers in this assay, from the lowest: compound 3; then compounds 1 and 2 (each within the scatter of the next).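

In this assay, this aromatic carbon proves able to shift the inhibition: putting the new group in place of fluoro gives a 4.0-fold lower number from compound 2 to compound 3 (0.60 log units; beyond the scatter), so compound 3 is a stronger inhibitor. Among these compounds, exchanging the group of compound 1 for the one in compound 3 at the same carbon gives a 3.5-fold lower number from compound 1 to compound 3 (0.54 log units; beyond the scatter), although compound 1 also carries a five-membered non-aromatic ring there and stays within the scatter of compound 2. Among these three compounds, then, a five-membered non-aromatic ring at this place does not on its own go with a lower number, and the group in compound 3 differs from that of compound 1 by also holding a six-membered aromatic ring of carbon only, but no measurement here explains the drop.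

The compounds shown leave open whether the six-membered aromatic ring alone accounts for the step or whether the whole group is needed, and how a simple amine or a carboxylic acid would read at this carbon. The rest of the molecule is the same in all three compounds, so they also leave open whether a longer chain elsewhere in the shared core would move the number.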